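Replacing an aromatic ring with a saturated one on the core

A few compounds are considered here, and "the series" means these few. Any claim that something is new, unique, unknown or untested is made for them only; others in the source may bear on it.

Measured compounds:
compound 1 `COc1cccc(Nc2cc3[nH]c(-c4cccc(C(F)(F)F)c4)nc3cn2)n1`: 85000 nM
compound 2 `FC(F)(F)c1ccc(Nc2cc3[nH]c(-c4cccc(C(F)(F)F)c4)nc3cn2)nc1`: < 5000 nM
compound 3 `O=C(O)c1ccc(Nc2cc3[nH]c(-c4cccc(C(F)(F)F)c4)nc3cn2)nc1`: < 5000 nM

In a physicochemical assay for solubility, using the shake flask method, measured as kinetic solubility, with a stated time of 20 h, at pH 2 (a higher number here means a more soluble compound, a lower number a less soluble compound), compound 1 gives 85000 nM. For compound 2 the value < 5000 nM is a limit of the assay, not a number. For compound 3 the value < 5000 nM is likewise a limit. Compound 2 thus stands at the floor of what is shown, where (the limit of < 5000 nM in this assay, at which 2 of the 3 values shown sit). The steps of an at least 17-fold lower number from compound 1 to compound 2 (1.23 log units; beyond the scatter) and an at least 17-fold lower number from compound 1 to compound 3 (1.23 log units; beyond the scatter) both run from compound 1 down to that limit, and the step that the two limits leave unreadable from compound 2 to compound 3 cannot be read.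

Compound 4 `FC1(F)CCC(c2nc3cnc(Nc4ccc(C(F)(F)F)cn4)cc3[nH]2)CC1` is the one not yet measured. Its change from compound 2 is 4,4-difluorocyclohexyl in place of 3-(trifluoromethyl)phenyl on an aromatic carbon. Within the data shown here, none of the measured steps touches that position on the core; all of them alter the group on the ring nitrogen instead, so they give no direct guide to the size or direction of this step in this assay.

With compound 2 at a limit, the expected value for compound 4 is estimated at 8000 nM, with a range from 2000 nM to 40000 nM. This estimate corresponds to an at least 1.6-fold higher number from compound 2 to compound 4 (0.20 log units; that floor lies within the scatter).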

Compound 4, solubility: 199000 nM
For compound 4 the middle estimate is 25-fold (1.40 log units) below the measured one; measured number outside the range, above it.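

Every earlier step in this assay changed the group on a nitrogen on an aromatic ring, leaving the aromatic carbon between two ring nitrogen atoms untested. Placing 4,4-difluorocyclohexyl there in place of 3-(trifluoromethyl)phenyl gives an at least 39-fold higher number from compound 2 to compound 4 (1.59 log units; beyond the scatter), so a change at this position alone lifts the compound clear of the floor while the 5-(trifluoromethyl)pyridin-2-yl group stays in place. The step starts from a limit and not from a number: the limit of < 5000 nM in this assay, at which 2 of the 4 values shown sit.

The compounds shown leave open whether the non-aromatic ring itself or its fluorine atoms carry this step, and how a plain cyclohexyl group or a piperidine ring would read here. Also open, on these data alone, is whether the same change would hold with the 6-methoxypyridin-2-yl group of compound 1 or the 5-carboxypyridin-2-yl group of compound 3.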